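A few compounds are considered here, and "the series" means these few. Any claim that something is new, unique, unknown or untested is made for them only; others in the source may bear on it.

Compound 1 `COc1cccc(Cc2cnc(CCc3ccc(-c4ccccc4C(=O)O)cc3)[nH]2)c1` was tested in an in vitro functional assay on cells for agonist activity at Bombesin receptor subtype-3 (Mus musculus), read by luminescence and calcium flux (on this read-out higher numbers stand for an effect only at larger amounts of compound and lower numbers for an effect already at smaller amounts), where compound 1 gives 79 nM. That is the lowest of the two numbers recorded so far. Within the data shown here, the only other measured compound, compound 2 `CCCCc1cnc(C(Cc2ccc(-c3ccccc3C(=O)O)cc2)C(C)C)[nH]1`, gives 2240 nM in this assay, a far larger number, and the gap between the two lies beyond the usual scatter. Compound 2 carries only saturated chains on the shared core, while compound 1 carries a ring with a methoxy group. The unmeasured compound 3 `CC(C)CCc1cnc(CCc2ccc(-c3ccccc3C(=O)O)cc2)[nH]1` exchanges that ring for a short saturated chain. (isobutyl in place of 3-methoxyphenyl on a saturated chain carbon bound to an aromatic carbon). Among the measured compounds shown here, no step between two measured compounds shows this exact exchange, so the expectation rests on compound 1 giving 79 nM and compound 2 giving 2240 nM. Because compound 2 gives 2240 nM with saturated chains only, a rise beyond the scatter is expected, namely a 6.3-fold higher number from compound 1 to compound 3 (0.80 log units; beyond the scatter). Compound 3 is therefore estimated at 500 nM, within a likely range from 150 nM to 2000 nM.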

Compound 3, half-maximal effective concentration: 10 nM
The estimate for compound 3 lay 50-fold (1.70 log units) above the measured number; measured number below the stated range.
By their numbers in this assay, from the lowest: compound 3; then compound 1; then compound 2.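

Among these compounds, this is the first change that can be read at a single place on the shared core: on a saturated chain carbon bound to an aromatic carbon, isobutyl replaces 3-methoxyphenyl. In this assay, that exchange gives a 7.9-fold lower number from compound 1 to compound 3 (0.90 log units; beyond the scatter), a step beyond the usual scatter. For these two compounds, then, a low number does not depend on the aromatic ring or its methoxy group at this place, as the entering group has no ring and no hydrogen-bond acceptor.

No measurement here accounts for the size or direction of this step. Going by these compounds, it also remains open whether the ring or the methoxy group matters more, and how a plain phenyl, a longer chain such as n-hexyl or an amine would read at this place.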